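A few compounds are considered here, and "the series" means these few. Any claim that something is new, unique, unknown or untested is made for them only; others in the source may bear on it.

compound 1 `O=C(O)CCNC(=O)c1ccc2c(c1)C(=O)N(CCC1CCNCC1)C2`: 27 nM
compound 2 `CCCCNS(=O)(=O)N[C@@H](CNC(=O)c1ccc2c(c1)C(=O)N(CCC1CCNCC1)C2)C(=O)O`: 19 nM
compound 3 `O=C(NC[C@H](NS(=O)(=O)c1ccccc1)C(=O)O)c1ccc2c(c1)C(=O)N(CCC1CCNCC1)C2`: 8 nM

All three values come from a functional assay for inhibition, with Homo sapiens as the target; on this read-out lower numbers stand for stronger inhibition and higher numbers for weaker inhibition. Compound 3 has the lowest number of the three, and its gaps to the other two lie beyond the scatter. Compound 4 `O=C(NC[C@H](NS(=O)(=O)Cc1ccccc1)C(=O)O)c1ccc2c(c1)C(=O)N(CCC1CCNCC1)C2` remains unmeasured. It differs from compound 3 by benzyl in place of phenyl on a sulfonyl sulfur. Among the compounds with values here, the only measured change on that sulfur is a 2.4-fold lower number from compound 2 to compound 3 (0.38 log units; beyond the scatter). Adding the substituted sulfonyl amino groups gave a 1.4-fold lower number from compound 1 to compound 2 (0.15 log units; within the scatter) and a 3.4-fold lower number from compound 1 to compound 3 (0.53 log units; beyond the scatter). Within the data shown here, no measured step covers benzyl itself, so only a small move toward a higher number is expected in this assay. The expected change is a 1.5-fold higher number from compound 3 to compound 4 (0.18 log units; within the scatter). For compound 4 the estimate is 12 nM, with an expected range of 4 nM to 32 nM.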

Compound 4, half-maximal inhibitory concentration: 4 nM
For compound 4 the middle estimate is 3.0-fold (0.48 log units) above the measured one, within the range that was stated.
By their numbers in this assay, from the lowest: compounds 4 and 3 (each within the scatter of the next); then compounds 2 and 1 (each within the scatter of the next).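

In this assay, benzyl on the sulfonyl sulfur cannot be told apart from phenyl (a 2.0-fold lower number from compound 3 to compound 4 (0.30 log units; within the scatter)), so this position accepts either group. The same sulfur shows a clearer gap when benzyl replaces butylamino (a 4.8-fold lower number from compound 2 to compound 4 (0.68 log units; beyond the scatter)), and (benzylsulfonyl)amino in place of hydrogen on the saturated chain carbon gives the largest step in the set (a 6.8-fold lower number from compound 1 to compound 4 (0.83 log units; beyond the scatter)). Nothing available explains these steps.

Still open, from the compounds shown here alone, is how phenethyl, a longer chain on the sulfonyl sulfur, would compare with benzyl. Going by these compounds, the effect of an amine or fluorine on the benzyl ring is also open.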